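From methyl to ethyl in the 1-phenylethyl series

The compounds below may be only part of what the source reports. "The series", "measured", "known", "first", "only" and "open" are said of these compounds alone.

Values in a functional assay for inhibition, with Rattus norvegicus as the target; on this read-out higher numbers stand for weaker inhibition and lower numbers for stronger inhibition:
- Compound 1 `C[C@H](/N=c1\c(O)c(O)\c1=N/c1ccc(C#N)cc1)c1ccccc1`: > 30000 nM
- Compound 2 `C[C@@H](/N=c1\c(O)c(O)\c1=N/c1ccc(C#N)cc1)C1CCCCC1`: 2600 nM

Compound 1 gives only a limit, > 30000 nM, and not a number. Its position therefore rests on (the limit of > 30000 nM in this assay, at which 1 of the 2 values shown sits).

Among the measured compounds shown here, the one measured step is an at least 11-fold lower number from compound 1 to compound 2 (1.06 log units; beyond the scatter). This large step, beyond the scatter, shows that this assay responds to a change in this substituent. It replaces the phenyl group, however, and compound 3 `CC[C@H](/N=c1\c(O)c(O)\c1=N/c1ccc(C#N)cc1)c1ccccc1` retains it.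

Compound 3 carries methyl in place of hydrogen on a saturated chain carbon, two bonds along the chain from an aromatic carbon and a double-bonded nitrogen: methyl in place of hydrogen on a saturated chain carbon, which also reads as methyl to ethyl. For the measured compounds named here, no measured step covers this change, so the step to compound 2 sets no size for it. Going by the values given here, with an at least 11-fold lower number from compound 1 to compound 2 (1.06 log units; beyond the scatter) as the only guide, a much smaller step is expected, at most modest and toward lower numbers, and possibly none beyond the scatter. A second limit would not be surprising.

The estimated step is an at least 1.2-fold lower number from compound 1 to compound 3 (0.07 log units; that floor lies within the scatter).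

The expected value for compound 3 is 25000 nM, with an estimated range of 6000 nM to 60000 nM.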

Compound 3, half-maximal inhibitory concentration: > 30000 nM
Compound 3: no number, only a limit; the forecaster's own chance of this, stated with the estimate: 55%; at least 1.2-fold (0.07 log units) between middle value and limit.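

No step can be read from compound 1 to compound 3 in this assay, as both compounds give only a limit and not a number: the limit of > 30000 nM in this assay, at which 2 of the 3 values shown sit.

The compounds shown leave open whether methyl in place of hydrogen on a saturated chain carbon changes inhibition at all, and if so, by how much.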